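A few compounds are considered here, and "the series" means these few. Any claim that something is new, unique, unknown or untested is made for them only; others in the source may bear on it.

Of the compounds shown here, three have been measured. In an assay on isolated protein for inhibition of Fatty-acid amide hydrolase 1 (Homo sapiens), read by fluorescence, with a stated time of 30 min (on this read-out higher numbers stand for weaker inhibition and lower numbers for stronger inhibition), compound 1 `CCOC(=O)c1cc(-c2cccc(OC(=O)NC3CCCCC3)c2)n(CC)n1` gives 101 nM, compound 2 `CCOC(=O)c1cc(-c2ccc(OC(=O)NC3CCCCC3)cc2)n(-c2ccccc2)n1` gives 268 nM, and compound 3 `NC(=O)c1cc(-c2cccc(OC(=O)NC3CCCCC3)c2)n(-c2ccccc2)n1` gives 169 nM. Compound 3 holds the second highest of the three numbers; its nearest neighbour is compound 2 and its furthest is compound 1, and both of those gaps lie within the scatter, so the three compounds stand as one group rather than in any order. Compound 4 `NC(=O)c1cc(-c2cccc(OC(=O)NC3CCCCC3)c2)n(-c2ccc(Cl)cc2)n1` differs from compound 3 by chloro in place of hydrogen on an aromatic carbon, para to a large group. Among the compounds with values here, no measured pair isolates this change, so the step is expected to be small, a 1.2-fold lower number from compound 3 to compound 4 (0.08 log units; within the scatter), with no direction settled beyond the scatter. Compound 4 is therefore estimated at 140 nM in this assay, within 60 nM to 330 nM.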

Compound 4, half-maximal inhibitory concentration: 174 nM
Compound 4: the middle estimate sits 1.2-fold (0.09 log units) below what was measured; measured number inside the range.
By their numbers in this assay, from the lowest: compounds 1, 3, 4 and 2 (each within the scatter of the next, the first and the last beyond it).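

In this assay, within the data shown here, phenyl to 4-chlorophenyl gives the first step in this set that isolates one change, and it reads a 1.0-fold higher number from compound 3 to compound 4 (0.01 log units; within the scatter) with the two compounds level. So a chloro on this ring, para to a large group, is tolerated on the amide compounds, which the earlier compounds could not show. No measured evidence bears on this result. The compounds shown leave open whether a methoxy, an amine or a carboxylic acid at this place would stay level too. They also leave open whether chloro behaves alike on the ethyl ester compounds.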